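Working notes: from compound 2 to compound 3

The source may hold more compounds than are shown below. What is called first, only, known or untested is meant among the compounds shown, and "the series" means these compounds.

Values so far in a physicochemical assay (on this read-out lower numbers stand for an effect already at smaller amounts and higher numbers for an effect only at larger amounts of compound), are as follows.

- compound 1 `COc1cc(/C=N/NC(=O)c2nn(-c3ccc(Cl)cc3Cl)c(-c3ccc(Cl)cc3)c2C)ccc1O` gives (3550000 nM)
- compound 2 `COc1cc(/C=N/NC(=O)c2nn(-c3ccc(F)cc3F)c(-c3ccc(F)cc3)c2C)ccc1O` gives (3540000 nM)

Compound 2 (3540000 nM) stands within the scatter of compound 1 (3550000 nM), so the two values cannot be told apart in this assay and give no order. For the measured compounds named here, no step between measured compounds that differ in one place is available yet.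

Compound 3 `COc1cc(/C=N/NC(=O)c2nn(-c3ccnc4cc(Cl)ccc34)c(-c3ccc(F)cc3)c2C)ccc1O` carries 7-chloroquinolin-4-yl in place of 2,4-difluorophenyl on an aromatic nitrogen. Going by the values given here, the data hold no measured example of this exchange. Among the compounds with values here, the only guide is the agreement of compound 1 (3550000 nM) with compound 2 (3540000 nM), so no step beyond the scatter is expected in either direction. The estimated change is small (a 1.0-fold lower number from compound 2 to compound 3 (0.00 log units; within the scatter)). The expected value for compound 3 is 3500000 nM (estimated range 1800000 nM to 6500000 nM).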

Compound 3, half-maximal effective concentration: 6450000 nM
Estimate against measurement, compound 3: 1.8-fold (0.27 log units) below; measured number inside the range.
By their numbers in this assay, from the lowest: compounds 2, 1 and 3 (each within the scatter of the next).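

In this assay the exchange of 2,4-difluorophenyl for 7-chloroquinolin-4-yl on the aromatic nitrogen gives a 1.8-fold higher number from compound 2 to compound 3 (0.26 log units; within the scatter) and so does not separate the two compounds on this read-out. For the compounds shown here, this is the first step read at this position, and it shows that an entering group with more heavy atoms and a hydrogen-bond acceptor, which 2,4-difluorophenyl lacks, still leaves the value within the scatter. No measurement is available that would explain this result.

Going by these compounds, whether an amine or a carboxylic acid carried on the group at this aromatic nitrogen would produce a step beyond the scatter remains open. Also open, on these data alone, is whether a plain longer alkyl chain on this nitrogen, in place of an aromatic group, would leave the value where it stands.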